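A chloro-bearing core, with pyrrolidinyl in place of pyridinylmethylamino

The source may hold more compounds than are shown below. What is called first, only, known or untested is meant among the compounds shown, and "the series" means these compounds.

Of the compounds shown here, two of this set have been tested in an assay on isolated protein for inhibition of interferon-induced, double-stranded RNA-activated protein kinase (Homo sapiens), read by luminescence, with a stated time of 10 min; a higher number here means a weaker inhibitor, a lower number a stronger inhibitor. Compound 1 `Cc1[nH]c2ccccc2c1-c1ccnc(N2CCCC2)n1` sits at the limit of the assay, giving > 100000 nM, which is not a number. Among the compounds with values here, compound 2 `Cc1[nH]c2ccc(Cl)cc2c1-c1ccnc(NCc2cccnc2)n1` gives the only actual number in this assay, 48000 nM. Compound 3 `Cc1[nH]c2ccc(Cl)cc2c1-c1ccnc(N2CCCC2)n1` keeps the core of compound 2 and differs by pyrrolidin-1-yl in place of ((pyridin-3-yl)methyl)amino on an aromatic carbon. Within the data shown here, no measured step informs this change, yet weaker inhibition beyond the scatter is expected, because compound 1 also carries pyrrolidin-1-yl and reaches only (the limit of > 100000 nM in this assay, at which 1 of the 2 values shown sits). The expected step is a 2.1-fold higher number from compound 2 to compound 3 (0.32 log units; beyond the scatter). Compound 3 is estimated at 100000 nM, within 40000 nM to 300000 nM.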

Compound 3, half-maximal inhibitory concentration: > 100000 nM
Compound 3: no number, only a limit (the forecaster's own chance of this, stated with the estimate: 55%); the middle value lies on the limit itself.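

Swapping ((pyridin-3-yl)methyl)amino for pyrrolidin-1-yl on the shared core gives an at least 2.0-fold higher number from compound 2 to compound 3 (0.31 log units; beyond the scatter) in this assay, so with the core held fixed, inhibition at this position depends on the group it carries. The full size of this loss stays hidden, because compound 3 reaches only a limit of the assay: the limit of > 100000 nM in this assay, at which 2 of the 3 values shown sit.

The step for chloro in place of hydrogen cannot be read, as both of its values are limits. From the compounds shown here alone, whether dimethylamino or benzylamino would keep the inhibition of compound 2 remains open.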